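Replacing the 6-(furan-2-yl)pyridin-3-yl group of compound 2

This account rests on a few compounds, and the source may have more. Where it says the series, first, only, none or still open, it means among the compounds named here.

Going by the values given here, in a functional assay on HCT-116 cells (Homo sapiens) for inhibition, with a stated time of 72 h (on this read-out higher numbers stand for weaker inhibition and lower numbers for stronger inhibition), compound 2 `NC1CCC(Nc2nc(NCc3ccc(-c4ccco4)nc3)c3ncn(C4CCCC4)c3n2)CC1` gives 86 nM and holds the lower of the two numbers so far, while compound 1 `NC1CCC(Nc2nc(NCc3ccc(-n4cccn4)cc3)c3ncn(C4CCCC4)c3n2)CC1` gives 320 nM in the same test. Compound 3 `NC1CCC(Nc2nc(NCc3cc(Cl)ccc3O)c3ncn(C4CCCC4)c3n2)CC1` differs from compound 2 by the change 5-chloro-2-hydroxyphenyl in place of 6-(furan-2-yl)pyridin-3-yl on a saturated chain carbon bound to a nitrogen on an aromatic ring that puts 5-chloro-2-hydroxyphenyl in place of 6-(furan-2-yl)pyridin-3-yl on a saturated chain carbon bound to a nitrogen on an aromatic ring. Among the compounds with values here, the only guide at this place is the modest step of a 3.7-fold lower number from compound 1 to compound 2 (0.57 log units; beyond the scatter) and no measured compound carries the new group. A similar modest move toward a higher number is expected, an estimated step of a 3.0-fold higher number from compound 2 to compound 3 (0.48 log units; beyond the scatter) with wide uncertainty. Compound 3 is estimated at 260 nM with a likely range from 70 nM to 1000 nM in this assay once measured.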

Compound 3, half-maximal inhibitory concentration: 350 nM
Estimate against measurement, compound 3: 1.3-fold (0.13 log units) below, and the stated range covers the measured number.
By their numbers in this assay, from the lowest: compound 2; then compounds 1 and 3 (each within the scatter of the next).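

In this assay the change to 5-chloro-2-hydroxyphenyl gives a 4.1-fold higher number from compound 2 to compound 3 (0.61 log units; beyond the scatter) and so does not keep the number of the 6-(furan-2-yl)pyridin-3-yl group at this place. Against the 4-(1H-pyrazol-1-yl)phenyl group, the same new group gives a 1.1-fold higher number from compound 1 to compound 3 (0.04 log units; within the scatter) and cannot be told apart from it here, although the two differ in their rings and substituents. No measured data explain either step.

The compounds shown leave open whether the chlorine or the hydroxyl alone accounts for the number of compound 3. Also open, from the compounds shown here alone, is how a plain phenyl or a 6-(furan-2-yl)phenyl group would read at this place.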